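Replacing the 4-hydroxycyclohexyl group of compound 2

This account rests on a few compounds, and the source may have more. Where it says the series, first, only, none or still open, it means among the compounds named here.

Measured so far in a functional assay on Shh Light II cells (Mus musculus) for inhibition, read by a luciferase reporter (on this read-out lower numbers stand for stronger inhibition and higher numbers for weaker inhibition), are two compounds:
compound 1 `O=C(NC1CCCCC1)N1CCN(c2nc(-c3ccc4ccccc4n3)no2)CC1` gives 53 nM in this assay
compound 2 `O=C(NC1CCC(O)CC1)N1CCC(c2nc(-c3ccc4ccccc4n3)no2)CC1` gives 2700 nM in this assay

Of the two numbers, compound 2 holds the higher, at 2700 nM against the lower number of compound 1, a gap beyond the usual scatter. Compound 3 `O=C(Nc1ccccc1C(F)(F)F)N1CCC(c2nc(-c3ccc4ccccc4n3)no2)CC1` has not yet been measured. It carries 2-(trifluoromethyl)phenyl in place of 4-hydroxycyclohexyl on an amide-type nitrogen and otherwise matches compound 2. Among the measured compounds shown here, no two measured compounds differ in one place only, so no measured step speaks directly to this change. Compound 1 at 53 nM differs from compound 2 in more than one place and is only a loose guide. A move to a lower number, beyond the scatter, is still expected in this assay for this change. The expected move is a 14-fold lower number from compound 2 to compound 3 (1.13 log units; beyond the scatter) in size. The estimated value for compound 3 is 200 nM with an expected range from 30 nM to 1500 nM at its ends.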

Compound 3, half-maximal inhibitory concentration: 700 nM
Beside the measured number, compound 3's estimate is 3.5-fold (0.54 log units) below it, within the range that was stated.
By their numbers in this assay, from the lowest: compound 1; then compound 3; then compound 2.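

In this assay, among the compounds shown here, the change of 2-(trifluoromethyl)phenyl for 4-hydroxycyclohexyl on the amide-type nitrogen gives a 3.9-fold lower number from compound 2 to compound 3 (0.59 log units; beyond the scatter), the first step that can be read at a single place. It shows that the number responds to the group at this position, and that an aromatic ring of carbon only is accepted there with a modest gain in inhibition. The step swaps the ring, removes the hydroxyl and adds the trifluoromethyl group all at once, so it cannot assign the gain to any one of these, and nothing measured here bears on why the number moved. The compounds shown leave open how a plain phenyl ring, a benzyl group or a methoxy group in place of trifluoromethyl would behave at this nitrogen. They also leave open whether the same step holds on the core of compound 1.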